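Demethylation of a pyrazole urea: removing the methyl from oxygen

The source may report more compounds than this note shows. Statements on the series, on what has been measured and on what is new or still open speak of the compounds shown alone.

Compound 2 `COc1cc(Cl)cc(-c2nn(-c3cccc(NC(=O)Nc4ccc(Cl)c(C(F)(F)F)c4)c3)cc2-c2ccncc2)c1` gives 37% in a functional assay on CCRF-CEM cells (Homo sapiens) for inhibition, read by sulforhodamine B assay, with a stated time of 48 h, tested at 1 uM (on this read-out higher numbers stand for a weaker effect at the one concentration tested and lower numbers for a stronger effect), the lowest of three numbers. Compound 1 `COc1cc(Cl)cc(-c2nn(-c3cccc(NC(=O)Nc4cccc(C(F)(F)F)c4)c3)cc2-c2ccncc2)c1` gives 56%, and the step of a number 19 percentage points lower from compound 1 to compound 2 (beyond the scatter) came with chloro in place of hydrogen on an aromatic carbon. Compound 3 `COc1cc(Cl)cc(-c2nn(-c3cccc(NC(=O)c4cccc(C(F)(F)F)c4)c3)cc2-c2ccncc2)c1` gives 53%; the step of a number 16 percentage points higher from compound 2 to compound 3 (beyond the scatter) is the nearest to compound 2. Compound 4 `O=C(Nc1cccc(-n2cc(-c3ccncc3)c(-c3cc(O)cc(Cl)c3)n2)c1)Nc1ccc(Cl)c(C(F)(F)F)c1` differs from compound 2 by hydrogen in place of methyl on an oxygen on an aromatic ring. Among the measured compounds shown here, none of the measured steps touches that oxygen; all concern the urea or amide side, so no precedent for this change exists in the set. With nothing to suggest a direction, the expected step of a number 5 percentage points higher from compound 2 to compound 4 (within the scatter) is small, and compound 4 is estimated at 42% with a range from 22% to 62%.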

Compound 4, a percentage reported as activity, at one concentration (the size of the read-out at that concentration, not a potency): 92%
Compound 4: the middle estimate sits 50 percentage points below what was measured; measured number above the stated range.
By their numbers in this assay, from the lowest: compound 2; then compounds 3 and 1 (each within the scatter of the next); then compound 4.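

Within this assay, the change from methoxy to hydroxy gives a number 55 percentage points higher from compound 2 to compound 4 (beyond the scatter) and so greatly weakens the effect at the one concentration tested. This step is larger than any seen among the earlier urea and amide changes, which left the 3-chloro-5-methoxyphenyl group untouched, and it shows that the effect depends strongly on what sits on this oxygen. No measurement at hand gives a reason for the step.

Going by these compounds, whether an ethoxy group or an amine in place of the methoxy would keep the stronger effect stays open. So does whether hydroxy in place of methoxy would cost as much on compound 1 or compound 3.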